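The compounds below may be only part of what the source reports. "The series", "measured", "known", "first", "only" and "open" are said of these compounds alone.

In a physicochemical assay for solubility, in phosphate buffer, with a stated time of 18 h (a higher number here means a more soluble compound, a lower number a less soluble compound), compound 3 `CC(C)(C)c1nc(-c2ccsc2)c2c(N)c(C#N)c(N)nc2n1` gives 40000 nM and compound 1 `Cc1nc(C(C)(C)C)nc2nc(N)c(C#N)c(N)c12` gives 37000 nM, so the two lie within the scatter of each other. Compound 2 `CC(C)(C)c1nc(C2CCCC2)c2c(N)c(C#N)c(N)nc2n1` gives < 1000 nM, which is a limit of the assay and not a number. Compound 4 `CC(C)(C)c1nc(-c2ccccc2)c2c(N)c(C#N)c(N)nc2n1` differs from compound 3 at one place: phenyl in place of thiophen-3-yl on an aromatic carbon. Two measured steps at this place bear on the change. Thiophen-3-yl in place of methyl gave a 1.1-fold higher number from compound 1 to compound 3 (0.03 log units; within the scatter), a step within the scatter, while thiophen-3-yl in place of cyclopentyl gave an at least 40-fold higher number from compound 2 to compound 3 (1.60 log units; beyond the scatter), a large one. Here one aromatic ring replaces another, so no step beyond the scatter is expected in this assay, though a slightly lower number is possible. The expected change is a 1.6-fold lower number from compound 3 to compound 4 (0.20 log units; within the scatter). For compound 4 the estimate is 25000 nM, with an expected range of 6000 nM to 60000 nM.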

Compound 4, solubility: 4000 nM
Compound 4: the middle estimate sits 6.3-fold (0.80 log units) above what was measured; measured number below the stated range.
By their numbers in this assay, from the lowest: compound 4; then compounds 1 and 3 (each within the scatter of the next). At a limit, below all of these: compound 2.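

In this assay one aromatic ring in place of another at this position is not a neutral change: phenyl gives a step beyond the scatter (a 10-fold lower number from compound 3 to compound 4 (1.00 log units; beyond the scatter)). An aromatic ring here therefore does not by itself match methyl, as phenyl also falls short of it (a 9.3-fold lower number from compound 1 to compound 4 (0.97 log units; beyond the scatter)) while thiophen-3-yl did not. Phenyl still stands apart from cyclopentyl (an at least 4.0-fold higher number from compound 2 to compound 4 (0.60 log units; beyond the scatter)), a step read from a limit of the assay and not a number: the limit of < 1000 nM in this assay, at which 1 of the 4 values shown sits.

Why the two rings part stays open. So does whether a pyridine ring, or a phenyl carrying an amine or a carboxylic acid, would shift the number at this place.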